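This account rests on a few compounds, and the source may have more. Where it says the series, first, only, none or still open, it means among the compounds named here.

Compound 1 `COc1cccc(/C=C/C(=O)c2cccc(-c3cccc(F)c3)c2)c1OC` gives 24100 nM in an assay on A549 cells for inhibition of transcription factor p65 (Homo sapiens), read by fluorescence, with a stated time of 2 h; a higher number here means a weaker inhibitor, a lower number a stronger inhibitor. Compound 2 `COc1ccccc1/C=C/C(=O)c1cccc(-c2cccc(F)c2)c1` differs from compound 1 in one place, (hydrogen in place of methoxy on an aromatic carbon), and in this assay compound 2 gives 35300 nM, a step of a 1.5-fold higher number from compound 1 to compound 2 (0.17 log units; within the scatter). Compound 3 `COc1cc(/C=C/C(=O)c2ccc(N)c(-c3ccc(F)cc3)c2)cc(OC)c1OC` rests on another core; how the two cores differ is not broken down here. In this assay compound 3 gives 11600 nM, the lowest of the three numbers, with the other two compounds beyond the scatter from it.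

Compound 4 `COc1ccc(/C=C/C(=O)c2ccc(N)c(-c3ccc(F)cc3)c2)cc1OC` has not yet been measured. It differs from compound 3 in one place, (hydrogen in place of methoxy on an aromatic carbon). This is the same kind of change as that made from compound 1 to compound 2, but not the same: in compound 3 the place is also meta to a methoxy group, which the place in compound 1 was not.

Because the earlier step of a 1.5-fold higher number from compound 1 to compound 2 (0.17 log units; within the scatter) stayed within the scatter, a step of similar size is expected, a 1.5-fold higher number from compound 3 to compound 4 (0.17 log units; within the scatter). Compound 4 is therefore expected to give about 17000 nM in this assay, with a likely range from 9000 nM to 35000 nM.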

Compound 4, half-maximal inhibitory concentration: > 50000 nM
Compound 4: a limit, no number; the forecaster's own chance of this, stated with the estimate: 5%; middle value at least 2.9-fold (0.46 log units) from the limit.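

In this assay the step on the core of compound 3 reads an at least 4.3-fold higher number from compound 3 to compound 4 (0.63 log units; beyond the scatter), and the same change does not carry over at one size from the core of compound 1: the same change on two cores in this assay, a 1.5-fold higher number (0.17 log units; within the scatter) from compound 1 to compound 2 and an at least 4.3-fold higher number (0.63 log units; beyond the scatter) from compound 3 to compound 4, at least 2.9-fold (0.46 log units) apart, beyond the scatter of two such steps. Compound 4 gives > 50000 nM, which is a limit of the assay and not a number: the limit of > 50000 nM in this assay, at which 1 of the 4 values shown sits. This shows that a step measured on one core is a poor guide to the other in this series, but it rests on one pair per core and does not show whether the rest of the core or the surroundings of the place, which in compound 3 is meta to a methoxy group, set the difference.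

The compounds shown leave open how a hydroxyl group or an ethoxy group at this place would read in this assay, since only methoxy and hydrogen are compared here. They also leave open whether the larger step belongs to the core of compound 3 in general or to this one place on it.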